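The source may report more compounds than this note shows. Statements on the series, on what has been measured and on what is new or still open speak of the compounds shown alone.

Three ureas have been measured in an ADME assay on the whole organism with Oryza sativa as the target, tested at 10 uM; on this read-out lower numbers stand for a stronger effect and higher numbers for a weaker effect at the one concentration tested. Compound 1 `CCc1ccc(NC(=O)N[C@@H](C)c2ccccc2)cc1` gives 91%. Compound 3 `CC(C)c1cccc(NC(=O)N[C@@H](C)c2ccccc2)c1` gives 86%. Compound 2 `CC(C)c1cccc(NC(=O)N[C@H](C)c2ccccc2)c1` gives 44%, the lowest of the three numbers, and so the strongest effect so far. Within the data shown here, the only single-point step among them is a number 42 percentage points higher from compound 2 to compound 3 (beyond the scatter), which is large and rests on nothing but the fact that compounds 2 and 3 differ only in the configuration as drawn — the two are mirror arrangements at one carbon.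

Compound 4 `C[C@@H](NC(=O)Nc1cccc(Cl)c1)c1ccccc1` keeps the configuration of compound 2 and differs in one place: chloro in place of isopropyl on an aromatic carbon. Among the measured compounds shown here, no measured pair changes this group, so the stereochemical step gives no guidance on its size or direction; the expectation therefore rests on the starting point of compound 2 alone. A small step, hardly beyond the scatter, is expected: a number 11 percentage points higher from compound 2 to compound 4 (beyond the scatter). For compound 4 in this assay the estimate is 55%, between 30% and 85%, with the wide range reflecting the missing precedent for this change.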

Compound 4, a percentage reported as activity, at one concentration (the size of the read-out at that concentration, not a potency): 83%
Estimate against measurement, compound 4: 28 percentage points below; low and high end bracket the measured number.
By their numbers in this assay, from the lowest: compound 2; then compounds 4, 3 and 1 (each within the scatter of the next).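

Chloro in place of isopropyl on an aromatic carbon, meta to a large group, gives a number 39 percentage points higher from compound 2 to compound 4 (beyond the scatter) in this assay and so takes away much of the effect seen with compound 2. Compound 4 keeps the drawn configuration of compound 2, which shows that this configuration alone does not secure the stronger effect and that the group at this place matters as well. Nothing measured about either group accounts for the size of this step.

The compounds shown leave open whether another group at this place, such as methoxy or tert-butyl, would hold the effect of compound 2 or lose it as chloro does. They also leave open whether the mirror arrangement at the chain carbon matters as much with chloro as it does with isopropyl.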